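Swapping Chloro for Nitro on a Hydroxyphenyl Arm

A few compounds are considered here, and "the series" means these few. Any claim that something is new, unique, unknown or untested is made for them only; others in the source may bear on it.

Of the compounds shown here, two built on the same core have been measured so far: compound 1 `CCOC(=O)N1CCC(N(Cc2cccc([N+](=O)[O-])c2)C(=O)N(C)C)CC1` and compound 2 `CCOC(=O)N1CCC(N(Cc2cc(Cl)ccc2O)C(=O)N(C)C)CC1`. In a functional assay on KB cells (Homo sapiens) for antiproliferative activity, read by MTT assay, with a stated time of 48 h (a lower number here means a stronger inhibitor, a higher number a weaker inhibitor), compound 1 gives 15600 nM. In the same test compound 2 gives 25700 nM. For the measured compounds named here, the only measured step, a 1.6-fold higher number from compound 1 to compound 2 (0.22 log units; within the scatter), stays within the scatter, so the two numbers cannot be told apart, and compound 2 stands level with compound 1 rather than above or below it.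

Compound 3 `CCOC(=O)N1CCC(N(Cc2cc([N+](=O)[O-])ccc2O)C(=O)N(C)C)CC1` is the next member: it differs from compound 2 by nitro in place of chloro on an aromatic carbon. Going by the values given here, the one measured step bears on this change, since it also exchanged a nitro group for a chloro group, although together with a hydroxy group, and it produced nothing beyond the scatter. On that basis compound 3 is expected to show a step of a 1.3-fold lower number from compound 2 to compound 3 (0.11 log units; within the scatter), that is, no change beyond the scatter, because a 1.6-fold higher number from compound 1 to compound 2 (0.22 log units; within the scatter) was itself within the scatter. The estimate for compound 3 in this assay is therefore 20000 nM, expected to fall between 8000 nM and 50000 nM.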

Compound 3, half-maximal inhibitory concentration: 24200 nM
The estimate for compound 3 lay 1.2-fold (0.08 log units) below the measured number; the range from low to high includes it.
By their numbers in this assay, from the lowest: compounds 1, 3 and 2 (each within the scatter of the next).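

At the aromatic carbon para to the hydroxy group, the exchange of chloro for nitro can now be read on its own, without a second difference mixed in: in this assay it gives a 1.1-fold lower number from compound 2 to compound 3 (0.03 log units; within the scatter) and so does not separate the two compounds. The hydroxy group can be read alone as well, since with the nitro group held in the molecule, hydroxy in place of hydrogen on an aromatic carbon gives a 1.6-fold higher number from compound 1 to compound 3 (0.19 log units; within the scatter) and this step also stays inside the usual scatter, so neither single change alters the picture among these three compounds. No measurement is available that could explain why these numbers stay level.

For the compounds shown here, it remains open whether a different group at this aromatic carbon, such as an amine or a carboxylic acid, would produce a step beyond the scatter, since chloro and nitro are the only two groups compared there. On these data alone, it is equally open whether a methoxy group in place of the hydroxy group, or a longer chain on the shared core, would move the number in either direction.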